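Adding a Methoxy Group: Cytotoxicity Expected Unchanged

The source may report more compounds than this note shows. Statements on the series, on what has been measured and on what is new or still open speak of the compounds shown alone.

Of the compounds shown here, three sharing one core have been tested in an ADME assay on THP-1 cells (Homo sapiens) for cytotoxicity, read by flow cytometry and propidium iodide staining, with a stated time of 72 h; a lower number here means a stronger inhibitor, a higher number a weaker inhibitor. Compound 1 `COc1ccccc1-c1cc(=O)c2cc(NC(C)=O)ccc2o1` gives 50000 nM, compound 2 `COc1ccccc1-c1cc(=O)c2cc(N)ccc2o1` gives 74000 nM, and compound 3 `Nc1ccc2oc(-c3ccccc3F)cc(=O)c2c1` gives 44000 nM. Compound 2 shows the highest of these three numbers, though its gaps to the others are within the scatter: a 1.5-fold higher number from compound 1 to compound 2 (0.17 log units; within the scatter) and a 1.7-fold lower number from compound 2 to compound 3 (0.23 log units; within the scatter). Compound 4 `COc1ccccc1-c1oc2ccc(N)cc2c(=O)c1OC` differs from compound 2 by methoxy in place of hydrogen on an aromatic carbon, on an aromatic carbon of a six-membered aromatic ring with 1 oxygen. Among the compounds with values here, no measured step adds a methoxy at this place, so the two known steps are the only guide; both lie within the scatter, which suggests no step beyond the scatter here either. Compound 4 is therefore expected to give 70000 nM, estimated between 30000 nM and 160000 nM. The expected step is a 1.1-fold lower number from compound 2 to compound 4 (0.02 log units; within the scatter).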

Compound 4, half-maximal inhibitory concentration: 116000 nM
Estimate against measurement, compound 4: 1.7-fold (0.22 log units) below; low and high end bracket the measured number.
By their numbers in this assay, from the lowest: compounds 3, 1, 2 and 4 (each within the scatter of the next, the first and the last beyond it).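

In this assay, within the data shown here, this is the first change at this position, on the aromatic carbon two atoms from the ring oxygen, and methoxy in place of hydrogen gives a 1.6-fold higher number from compound 2 to compound 4 (0.20 log units; within the scatter). The position therefore accepts a methoxy group with no step beyond the scatter, at least alongside the groups of compound 2. No measurement shown offers an explanation for this result.

Whether a single step at this position can exceed the scatter remains open, since only methoxy is shown there. An amine, a carboxylic acid or a longer chain such as butoxy could behave differently.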